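Inverting One Stereocentre in a Cell Growth Series

The source may report more compounds than this note shows. Statements on the series, on what has been measured and on what is new or still open speak of the compounds shown alone.

Compound 1 `CC1=NN(c2ccccc2)C(=O)[C@@]12C(=O)C=CC[C@@H]2c1cccc(C)c1`: 6800 nM
Compound 2 `CC1=NN(c2ccccc2)C(=O)[C@@]12C(=O)C=CC[C@H]2c1ccccc1`: 5500 nM

In a functional assay on MDA-MB-231 cells (Homo sapiens) for inhibition, read by MTT assay, with a stated time of 72 h (on this read-out higher numbers stand for weaker inhibition and lower numbers for stronger inhibition), compound 2 gives 5500 nM and compound 1 gives 6800 nM. These two numbers lie within the usual scatter of each other, so compound 2 does not stand apart from compound 1.

The next compound to be tested is compound 3 `CC1=NN(c2ccccc2)C(=O)[C@@]12C(=O)C=CC[C@@H]2c1ccccc1`, which has the same atoms and bonds as compound 2 and differs only in configuration as drawn: the two compounds have the same atoms and bonds and differ only in configuration as drawn: 1 of 2 stereo elements differ; a stereocentre at a saturated ring carbon is drawn S in compound 2 and R in compound 3. A stereocentre at a saturated ring carbon is drawn S in compound 2 and R in compound 3.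

Among the compounds with values here, no measured pair shows what such a change does in this assay, so the expectation is a cautious one. It rests on the closeness of compound 1 at 6800 nM and compound 2 at 5500 nM. The estimated step of a 1.2-fold higher number from compound 2 to compound 3 (0.07 log units; within the scatter) is slightly upward and not expected to exceed the scatter. A larger step in either direction cannot be excluded. For compound 3 the expected value is 6500 nM, with an estimated range of 2500 nM to 16000 nM.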

Compound 3, half-maximal inhibitory concentration: 9310 nM
Beside the measured number, compound 3's estimate is 1.4-fold (0.16 log units) below it; measured number inside the range.
By their numbers in this assay, from the lowest: compounds 2, 1 and 3 (each within the scatter of the next).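

Within the data shown here, the pair of compound 2 and compound 3 gives the first direct reading of inverting the saturated ring carbon stereocentre in this assay, and the step is a 1.7-fold higher number from compound 2 to compound 3 (0.23 log units; within the scatter), so going from S to R as drawn does not carry the number beyond the scatter. The comparison isolates that single stereocentre, as nothing else separates the two structures: the fact that compounds 2 and 3 differ only in the configuration as drawn. The second step, hydrogen in place of methyl on an aromatic carbon, is a 1.4-fold higher number from compound 1 to compound 3 (0.14 log units; within the scatter), which shows that this swap also stays within the scatter when the configuration as drawn is held the same.

The compounds shown leave open whether the stereocentre would count for more with a different group on that aromatic carbon, such as a methoxy group, a chlorine atom or an amine, since only methyl and hydrogen stand there so far. They also leave open what inverting the second stereo element would do, alone or together with the first, since only one of the two differs within the pair of compound 2 and compound 3.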